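The source may hold more compounds than are shown below. What is called first, only, known or untested is meant among the compounds shown, and "the series" means these compounds.

Among the compounds with values here, compound 2 `COc1cccc(Cl)c1C(=O)Nc1c[nH]nc1C(=O)NC1CCN(S(=O)(=O)c2cccc(NC(=O)/C=C/CN(C)C)c2)CC1` gives 50 nM in an assay on HEK293 cells for inhibition of cyclin-dependent kinase 14 (Homo sapiens), with a stated time of 4 h (a higher number here means a weaker inhibitor, a lower number a stronger inhibitor), the only number among the values shown. Compound 1 `COc1cccc(OC)c1C(=O)Nc1c[nH]nc1C(=O)NC1CCN(S(=O)(=O)c2cccc(NC(=O)/C=C/CN(C)C)c2)CC1` sits at a limit of the assay, reported as > 1000 nM in this assay (the limit of > 1000 nM in this assay, at which 1 of the 2 values shown sits). The step of an at least 20-fold lower number from compound 1 to compound 2 (1.30 log units; beyond the scatter) shows how strongly the substitution on that ring moves the result. Compound 3 `CN(C)C/C=C/C(=O)Nc1cccc(S(=O)(=O)N2CCC(NC(=O)c3n[nH]cc3NC(=O)c3ccccc3)CC2)c1` differs from compound 2 by phenyl in place of 2-chloro-6-methoxyphenyl on a carbonyl carbon. Within the data shown here, no measured step covers the unsubstituted ring, so the outlook rests on that single step; a weaker inhibitor is expected, with a 10-fold higher number from compound 2 to compound 3 (1.00 log units; beyond the scatter). Compound 3 is therefore estimated at 500 nM in this assay, between 100 nM and 3000 nM.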

Compound 3, half-maximal inhibitory concentration: 1000 nM
For compound 3 the middle estimate is 2.0-fold (0.30 log units) below the measured one, within the range that was stated.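

On the carbonyl carbon, phenyl in place of 2-chloro-6-methoxyphenyl gives a 20-fold higher number from compound 2 to compound 3 (1.30 log units; beyond the scatter), so the substituents on this ring matter to the result. On the same carbon, phenyl in place of 2,6-dimethoxyphenyl gives a number no higher from compound 1 to compound 3 (the limit leaves the size open). Compound 1 stands at a limit of the assay, so the size of this step cannot be read: the limit of > 1000 nM in this assay, at which 1 of the 3 values shown sits.

The compounds shown leave open whether the chloro or the methoxy group alone accounts for the step. They also leave open how a ring carrying bromo, methyl or trifluoromethyl in place of chloro would read.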